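Anilide series on a dimethylaminobiphenyl scaffold: tert-butyl amide

The source may hold more compounds than are shown below. What is called first, only, known or untested is meant among the compounds shown, and "the series" means these compounds.

Measured so far:
compound 1 `CN(C)c1ccc(-c2cccc(N)c2)cc1` 100000 nM
compound 2 `CN(C)c1ccc(-c2cccc(NC(=O)Oc3ccccc3)c2)cc1` 73000 nM

In an assay on COS-7 cells for inhibition of patatin-like phospholipase domain-containing protein 2 (Mus musculus) (a higher number here means a weaker inhibitor, a lower number a stronger inhibitor), compound 1 gives 100000 nM and compound 2 gives 73000 nM. The two numbers lie within the usual scatter of each other, so nothing separates compound 2 from compound 1 on this assay; both sit at the weak end of what the assay resolves.

Compound 3 `CN(C)c1ccc(-c2cccc(NC(=O)C(C)(C)C)c2)cc1` differs from compound 2 in one place: tert-butyl in place of phenoxy on a carbonyl carbon. No step between two measured compounds is available to size this change, and no reason is visible in the two numbers for a shift in either direction. Compound 3 is therefore expected to stay in the same weak region as compound 2, with a step of a 1.0-fold lower number from compound 2 to compound 3 (0.02 log units; within the scatter) that should fall within the scatter. For compound 3 the estimate is 70000 nM, with a range from 20000 nM to 200000 nM.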

Compound 3, half-maximal inhibitory concentration: > 200000 nM
Compound 3: a limit, no number; the forecaster's own chance of this, stated with the estimate: 30%; at least 2.8-fold (0.45 log units) between middle value and limit.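

Among the compounds shown here, the change of phenoxy to tert-butyl on a carbonyl carbon gives an at least 2.7-fold higher number from compound 2 to compound 3 (0.43 log units; beyond the scatter) and is the first step that lies beyond the scatter, so the group on this carbonyl carbon does affect the reading. Setting (tert-butyl)carbonyl in place of hydrogen on the aromatic-ring nitrogen gives an at least 2.0-fold higher number from compound 1 to compound 3 (0.30 log units; that floor lies within the scatter) and, with that floor inside the scatter, this step alone establishes no real difference. In this assay compound 3 gives > 200000 nM as a limit and not a number: the limit of > 200000 nM in this assay, at which 1 of the 3 values shown sits.

From the compounds shown here alone, the true size of both steps stays open, as does whether the ring or the oxygen of phenoxy accounts for the step from the carbamate. Also open, going by these compounds, is how an aminomethyl group, a carboxylic acid or a longer alkyl chain on this carbonyl carbon would read.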